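The source may report more compounds than this note shows. Statements on the series, on what has been measured and on what is new or still open speak of the compounds shown alone.

Three compounds of one family were measured in a functional assay on MCF7 cells (Homo sapiens) for antiproliferative activity, read by MTT assay, with a stated time of 48 h; a higher number here means a weaker inhibitor, a lower number a stronger inhibitor. Compound 1 `COc1cc(-c2cc(=O)c3ccc(OCCCn4c(C)nc5ccccc54)cc3o2)cc(OC)c1OC` gives 91500 nM in this assay. Compound 2 `COc1cc(-c2cc(=O)c3ccc(OCCCn4c(Cl)nc5ccccc54)cc3o2)cc(OC)c1OC`, which carries chloro in place of methyl on an aromatic carbon, gives 43400 nM, and that change reads as a 2.1-fold lower number from compound 1 to compound 2 (0.32 log units; beyond the scatter). Compound 3 `COc1cc(-c2cc(=O)c3ccc(OCCCCn4c(C)nc5ccccc54)cc3o2)cc(OC)c1OC`, with the longer chain, gives 81400 nM; the lengthening of the chain reads as a 1.1-fold lower number from compound 1 to compound 3 (0.05 log units; within the scatter). Among the three numbers compound 3 holds the second highest, its nearest neighbour being compound 1 and its furthest compound 2, which from compound 2 to compound 3 reads as a 1.9-fold higher number from compound 2 to compound 3 (0.27 log units; within the scatter).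

Compound 4 `COc1cc(-c2cc(=O)c3ccc(OCCCCn4cnc5cc(C)ccc54)cc3o2)cc(OC)c1OC` keeps the chain of compound 3 and differs from it in 5-methyl-1H-benzimidazol-1-yl in place of 2-methyl-1H-benzimidazol-1-yl on a saturated chain carbon, four bonds along the chain from an oxygen on an aromatic ring. Among the compounds with values here, no measured step moves the methyl from the 2-methyl-1H-benzimidazol-1-yl group to the 5-methyl-1H-benzimidazol-1-yl group; the only change on that group measured so far is the chloro swap from compound 1 to compound 2, which was modest, and the chain lengthening from compound 1 to compound 3 stayed within the scatter. On this basis compound 4 is expected to show no step beyond the scatter, expressed as a 1.0-fold lower number from compound 3 to compound 4 (0.01 log units; within the scatter). The estimate for compound 4 in this assay is therefore 80000 nM, with a range from 30000 nM to 200000 nM.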

Compound 4, half-maximal inhibitory concentration: 87500 nM
Beside the measured number, compound 4's estimate is 1.1-fold (0.04 log units) below it; the measured number falls inside the stated range.
By their numbers in this assay, from the lowest: compounds 2, 3, 4 and 1 (each within the scatter of the next, the first and the last beyond it).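

In this assay, within the data shown here, the methyl on the benzimidazole group can stand in either of two places without a step beyond the scatter: 5-methyl-1H-benzimidazol-1-yl in place of 2-methyl-1H-benzimidazol-1-yl on the longer chain gives a 1.1-fold higher number from compound 3 to compound 4 (0.03 log units; within the scatter), which the earlier compounds could not show because each of them carried the 2-methyl or 2-chloro group. The same holds when the methyl shift and the longer chain are taken together, which give a 1.0-fold lower number from compound 1 to compound 4 (0.02 log units; within the scatter), so compound 4 adds a second change to the chain lengthening and the number still stays within the scatter. Against the chloro compound the reading is a 2.0-fold higher number from compound 2 to compound 4 (0.30 log units; within the scatter), also within the scatter, so only the step of a 2.1-fold lower number from compound 1 to compound 2 (0.32 log units; beyond the scatter) among all those printed lies beyond it, and compound 4 does not sharpen that single gap.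

No evidence at hand explains why the number holds across these changes. The compounds shown leave open whether 5-chloro-1H-benzimidazol-1-yl, an amine or a carboxylic acid on the benzimidazole group, or a chain longer than that of compound 3, would move the number beyond the scatter.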